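The source may report more compounds than this note shows. Statements on the series, on what has been measured and on what is new or still open speak of the compounds shown alone.

Measured so far:
Compound 1 `CCN(CC)CCCNc1nc(-c2ccc(NC(=O)Nc3ccc(C)cc3)cc2)nc2c(Cl)c(Cl)sc12`: 3320 nM in a functional assay on MKN-45 cells (Homo sapiens) for cytotoxicity, read by MTT assay, with a stated time of 72 h; on this read-out higher numbers stand for weaker inhibition and lower numbers for stronger inhibition
Compound 2 `CCN(CC)CCNc1nc(-c2ccc(NC(=O)Nc3ccccc3Cl)cc2)nc2c(Cl)c(Cl)sc12`: 1130 nM in this assay

Compound 2 stands lowest of the two numbers recorded in this assay; its nearest neighbour is compound 1, whose number is higher by a gap that lies beyond the usual scatter. The two compounds differ in more than one place, so nothing can be read from them as a single step; their values simply stand side by side.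

Compound 3 `CCN(CC)CCNc1nc(-c2ccc(NC(=O)Nc3ccc(C)cc3)cc2)nc2c(Cl)c(Cl)sc12` has not yet been measured in this assay. It is reached from compound 2 by one change, (4-methylphenyl in place of 2-chlorophenyl on an amide-type nitrogen). The same 4-methylphenyl group is carried by compound 1, which sits on the weaker side of the recorded numbers, but compound 1 also differs from compound 2 elsewhere, so its value cannot be assigned to this change alone. Among the measured compounds shown here, with no directly comparable step to lean on, the expected step from compound 2 to compound 3 is a 1.8-fold higher number from compound 2 to compound 3 (0.25 log units; within the scatter), a modest weakening that may well fall within the scatter. Compound 3 is therefore estimated at 2000 nM, with a plausible range from 700 nM to 6000 nM.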

Compound 3, half-maximal inhibitory concentration: 1450 nM
Beside the measured number, compound 3's estimate is 1.4-fold (0.14 log units) above it; measured number inside the range.
By their numbers in this assay, from the lowest: compounds 2 and 3 (each within the scatter of the next); then compound 1.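

In this assay, 4-methylphenyl in place of 2-chlorophenyl on the amide-type nitrogen gives a 1.3-fold higher number from compound 2 to compound 3 (0.11 log units; within the scatter) and so leaves these two groups indistinguishable on this read-out, which no single-place comparison could show before. Among the compounds shown here, compound 3 also isolates the chain for the first time: diethylamino in place of (diethylamino)methyl on the saturated chain carbon gives a 2.3-fold lower number from compound 1 to compound 3 (0.36 log units; beyond the scatter), a modest step, and the only one of the two changes that lies beyond the scatter. Nothing available here explains the size of either step.

Because the chlorine and methyl substituents are named at different ring positions, the comparison cannot separate the identity of the substituent from its placement, and groups such as 4-chlorophenyl, 2-methylphenyl or unsubstituted phenyl would be needed to do so. Going by these compounds, the chain step is read only with 4-methylphenyl on the amide-type nitrogen, so it remains open whether it carries over to 2-chlorophenyl, and how a longer chain or a pyrrolidine or morpholine in place of diethylamino would read.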